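Swapping 4-bromophenyl for 3,5-dimethylphenyl on a sulfur

The source may report more compounds than this note shows. Statements on the series, on what has been measured and on what is new or still open speak of the compounds shown alone.

Measured in a functional assay on A-375 cells (Homo sapiens) for inhibition, read by CCK-8 assay, with a stated time of 72 h, tested at 2 uM; a higher number here means more inhibition of growth at the concentration tested, a lower number less inhibition of growth:
- compound 1 `COc1ccc(SCc2ccc(C(=O)Nc3ccccc3N)cc2)cc1`: 10.2%
- compound 2 `Nc1ccccc1NC(=O)c1ccc(CSc2ccc(Br)cc2)cc1`: 4.35%

Only these two compounds have been measured so far. Compound 2, at 4.35%, cannot be told apart from compound 1, at 10.2%, since the gap between them lies within the usual scatter of this kind of measurement.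

The next compound is compound 3 `Cc1cc(C)cc(SCc2ccc(C(=O)Nc3ccccc3N)cc2)c1`, which keeps the shared core and carries 3,5-dimethylphenyl in place of 4-bromophenyl on a sulfur.

Going by the values given here, one measured step bears on this change. Exchanging a methoxy group for a bromo group gives a number 5.9 percentage points lower from compound 1 to compound 2 (within the scatter), and that step stays within the scatter. Among the compounds with values here, it is only a loose guide, as no compound with a 3,5-dimethylphenyl group has been measured yet. With this single small step as the evidence, no step beyond the scatter is expected in this assay, and no direction can be called. The estimated step is a number 3.7 percentage points higher from compound 2 to compound 3 (within the scatter). For compound 3 the expected value is 8%, with an estimated range of 0% to 20%.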

Compound 3, percent growth inhibition at one concentration: 48.5%
Beside the measured number, compound 3's estimate is 40.5 percentage points below it, outside the stated range (above it).
By their numbers in this assay, from the lowest: compounds 2 and 1 (each within the scatter of the next); then compound 3.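

The aryl group on the sulfur can strongly change growth inhibition in this assay: 3,5-dimethylphenyl in place of 4-bromophenyl gives a number 44.2 percentage points higher from compound 2 to compound 3 (beyond the scatter), and 3,5-dimethylphenyl in place of 4-methoxyphenyl gives a number 38.3 percentage points higher from compound 1 to compound 3 (beyond the scatter). Compound 1 and compound 2 lie within the scatter of each other, so that pair alone gave no sign of this sensitivity, whereas compound 3 stands clearly apart from both and shows that the choice of aryl group here can decide whether the compound has a sizeable effect at the concentration tested. Nothing available explains why the dimethyl-substituted ring behaves so differently from the other two rings.

The three compounds cannot show whether both methyl groups are needed, as a plain phenyl, a 3-methylphenyl or a 3,5-dichlorophenyl group on the sulfur would begin to test. They also leave open whether the sulfur itself matters, which an oxygen or a methylene link in its place would address, and how compound 3 would behave at other concentrations.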